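A few compounds are considered here, and "the series" means these few. Any claim that something is new, unique, unknown or untested is made for them only; others in the source may bear on it.

The measured compounds in a functional assay on EC9706 cells (Homo sapiens) for cytotoxicity, read by MTT assay, with a stated time of 72 h; on this read-out higher numbers stand for weaker inhibition and lower numbers for stronger inhibition:

Compound 1 `COc1ccc(NC(=O)CSC(=S)N[C@H]2CCOC2=O)cc1` gives > 128000 nM.
Compound 2 `CCCCSC(=S)N[C@H]1CCOC1=O` gives > 128000 nM.
Compound 3 `O=C(CCl)Nc1ccc(C(=O)/C=C/c2ccc(Cl)cc2)cc1` gives 8340 nM.

Compound 1 stands at a limit of this assay, not at a number, so that its value is only known to lie beyond that limit. Compound 2 likewise reaches only a limit of this assay. Compound 3 alone gives a number, well inside the measured range. The two limits are the same one: the limit of > 128000 nM in this assay, at which 2 of the 3 values shown sit.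

Compound 4 `O=C(CSC(=S)N[C@H]1CCOC1=O)Nc1ccc(C(=O)/C=C/c2ccccc2)cc1` keeps the dithiocarbamate lactone of compound 1 and changes one position of the aromatic ring: (2-phenylethenyl)carbonyl in place of methoxy on an aromatic carbon. Within the data shown here, no measured pair in this set shows such a step directly. Compound 3, which carries the same (2-phenylethenyl)carbonyl grouping on its amide-bearing ring, gives a measurable number, whereas compound 1 with methoxy gives none. On that basis compound 4 is expected to gain clearly against compound 1, a step estimated as an at least 10-fold lower number from compound 1 to compound 4 (1.02 log units; beyond the scatter), beyond the scatter. Compound 4 is estimated at 12000 nM, in a range from 3000 nM to 60000 nM.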

Compound 4, half-maximal inhibitory concentration: 44900 nM
Beside the measured number, compound 4's estimate is 3.7-fold (0.57 log units) below it; low and high end bracket the measured number.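

Among the compounds carrying the dithiocarbamate lactone, compound 4 is the first to give a number in this assay. Placing (2-phenylethenyl)carbonyl in place of methoxy on an aromatic carbon, para to a large group, gives an at least 2.8-fold lower number from compound 1 to compound 4 (0.45 log units; beyond the scatter), so this position does affect the read-out and a much larger group there keeps measurable activity. The step is only a bound, not a full size, because compound 1 gives a limit of the assay and not a number: the limit of > 128000 nM in this assay, at which 2 of the 4 values shown sit.

The compounds shown do not separate what the added aromatic ring contributes from what the double bond and the carbonyl contribute. On these data alone, whether a benzoyl group, an amine or a carboxylic acid at this position would also give a number remains open.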